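Shortening the alkyl chain on an azepane dithiocarbamate phosphate

The source may hold more compounds than are shown below. What is called first, only, known or untested is meant among the compounds shown, and "the series" means these compounds.

Of the compounds shown here, three have been measured in a functional assay on PC-3 cells (Homo sapiens) for inhibition, read by MTT assay, with stated times of 18 h and 4 h; a higher number here means a weaker inhibitor, a lower number a stronger inhibitor. Compound 1 `CCCCCCCCCCCCCCCCOP(=O)(O)OCCSC(=S)N1CCCCC1` gives 34300 nM. Compound 2 `CCCOP(=O)(O)OCCSC(=S)N1CCCC1` reaches only the limit of the assay, > 100000 nM, so no number is known for it. Compound 3 `CCCCCCCCOP(=O)(O)OCCSC(=S)N1CCCCCC1` gives 56800 nM, the higher of the two numbers, though its gap to compound 1 lies within the scatter, so the two cannot be ordered. One of the three values sits at the limit (the limit of > 100000 nM in this assay, at which 1 of the 3 values shown sits).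

Compound 4 `CCCCCCOP(=O)(O)OCCSC(=S)N1CCCCCC1` is still to be measured. Its change from compound 3 is hydrogen in place of ethyl on a saturated chain carbon, six bonds along the chain from an oxygen on an unsaturated carbon, so the chain is shortened. Across the measured compounds, compound 2, with the propyl chain, reaches the limit, while compound 1, with the longest chain, gives the lowest number, so a shorter chain is expected to weaken inhibition somewhat, and compound 2 shows this might push the value to the limit. The step expected is a 1.5-fold higher number from compound 3 to compound 4 (0.18 log units; within the scatter), toward a weaker inhibitor. Compound 4 is therefore estimated at 85000 nM, with a range from 40000 nM to 200000 nM.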

Compound 4, half-maximal inhibitory concentration: > 100000 nM
Compound 4 gave a limit, no number (the forecaster's own chance of this, stated with the estimate: 35%); at least 1.1-fold (0.07 log units) between middle value and limit.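

In this assay compound 4 gives > 100000 nM, which is a limit of the assay and not a number. Hydrogen in place of ethyl at this place on the chain gives an at least 1.7-fold higher number from compound 3 to compound 4 (0.24 log units; that floor lies within the scatter), so shortening the chain here leaves no measurable inhibition in this assay, although the true size of the step is unknown and its floor alone does not clear the usual scatter. For the compounds shown here, the earlier compounds all differ from one another in more than one place, so this is the first reading of the chain alone, and it also shows how little room the assay leaves at this end of the series: the limit of > 100000 nM in this assay, at which 2 of the 4 values shown sit.

From the compounds shown here alone, whether a longer chain on the core of compound 3 would give a lower number remains open. So does whether an amine or a carboxylic acid at the end of the chain would be tolerated.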